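Swapping methyl for methoxy on a growth-inhibiting oxindole pair

The source may hold more compounds than are shown below. What is called first, only, known or untested is meant among the compounds shown, and "the series" means these compounds.

Two compounds with the same core were tested in a functional assay on HL-60 cells (Homo sapiens) for inhibition, read by CCK-8 assay, with a stated time of 72 h, tested at 20 uM; on this read-out lower numbers stand for less inhibition of growth and higher numbers for more inhibition of growth at the one concentration tested. Compound 1, with the structure `CCOC(=O)/C=C1/C(=O)Nc2ccccc21`, carries an ethyl ester on its exocyclic double bond and no group on the benzene part of its core; in this assay compound 1 gives 77.7%. Compound 2, with the structure `Cc1ccc2c(c1)/C(=C\C(=O)OC(C)(C)C)C(=O)N2`, instead carries a tert-butyl ester and a methyl group on an aromatic carbon; in this assay compound 2 gives 94.6%. Of the two numbers, compound 2 stands highest, and its gap to compound 1 lies beyond the usual scatter. These two compounds differ in two places at once, so nothing separates the share of the ester from that of the methyl group.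

Compound 3, with the structure `COc1ccc2c(c1)/C(=C\C(=O)OC(C)(C)C)C(=O)N2`, has not yet been measured. Its change from compound 2 is methoxy in place of methyl on an aromatic carbon. Among the measured compounds shown here, no measured pair shows what this swap does here, so the expected step is small and in no firm direction: a number 6.6 percentage points lower from compound 2 to compound 3 (within the scatter) is the estimated change, most likely within the scatter. Compound 3 is therefore expected to give about 88% in this assay, with a plausible range from 70% to 98%.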

Compound 3, percent growth inhibition at one concentration: 94.2%
Compound 3: the middle estimate sits 6.2 percentage points below what was measured; the measured number falls inside the stated range.
By their numbers in this assay, from the lowest: compound 1; then compounds 3 and 2 (each within the scatter of the next).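

With the tert-butyl ester kept in place, compound 2 and compound 3 differ only on one aromatic carbon, so this pair isolates a single change, which the earlier pair could not do. In this assay, methoxy in place of methyl gives a number 0.4 percentage points lower from compound 2 to compound 3 (within the scatter), so replacing a group that has no hydrogen-bond acceptor with one that has a hydrogen-bond acceptor leaves no readable difference at this position, with compound 2 at 94.6% and compound 3 at 94.2% at the one concentration tested. No available measurement offers an explanation for this outcome.

Both numbers lie close to the top of the percent scale, so a gap between these two compounds could stay hidden at this single concentration, and an amine or a carboxylic acid on the same carbon would test this position with a very different kind of group. As far as these compounds go, compound 1 still differs from compound 2 and compound 3 in two places, so the share of the ester in its lower number also remains open.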